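Swapping Trifluoromethyl for Amino on a Chalcone-Type Series

The compounds below may be only part of what the source reports. "The series", "measured", "known", "first", "only" and "open" are said of these compounds alone.

compound 1 `COc1cc(OC)c(C(=O)/C=C/c2ccc(O)c(O)c2)c(OC)c1`: 15800 nM
compound 2 `COc1cc(OC)c(C(=O)/C=C/c2ccc(C(F)(F)F)cc2)c(OC)c1`: 5100 nM

The two measured compounds were tested in a functional assay on HeLa cells (Homo sapiens) for inhibition, read by MTT assay, with a stated time of 72 h; a higher number here means a weaker inhibitor, a lower number a stronger inhibitor. Of the pair, compound 2 gives the lower number at 5100 nM, and its gap to compound 1 at 15800 nM lies beyond the scatter of repeated measurements. That makes compound 2 the stronger inhibitor of the two.

The next compound, compound 3 `COc1cc(OC)c(C(=O)/C=C/c2ccc(N)cc2)c(OC)c1`, keeps the shared core of compound 2 and changes one group: amino in place of trifluoromethyl on an aromatic carbon, para to a large group (amino in place of trifluoromethyl on an aromatic carbon). Going by the values given here, no step between measured compounds that differ in one place is available, so the expectation rests on thin ground. Among the compounds with values here, compound 1, at 15800 nM, is the only other guide, and it leans the expectation towards a higher number than that of compound 2.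

In this assay, a modest weakening is expected, one that may not clear the usual scatter, and the estimated step is a 1.8-fold higher number from compound 2 to compound 3 (0.25 log units; within the scatter). The estimate for compound 3 is 9000 nM, with an expected range of 3000 nM to 25000 nM.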

Compound 3, half-maximal inhibitory concentration: > 50000 nM
Compound 3: a limit, no number; the forecaster's own chance of this, stated with the estimate: 5%; middle value at least 5.5-fold (0.74 log units) from the limit.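

Compound 3 stands in this assay only as a limit, not as a number: the limit of > 50000 nM in this assay, at which 1 of the 3 values shown sits. On an aromatic carbon para to a large group, amino in place of trifluoromethyl gives an at least 9.8-fold higher number from compound 2 to compound 3 (0.99 log units; beyond the scatter), which shows that the reading in this assay is sensitive to the group at this position, something the first two compounds, which differ in more than one place, could not show. Setting 4-aminophenyl in place of 3,4-dihydroxyphenyl gives an at least 3.1-fold higher number from compound 1 to compound 3 (0.50 log units; beyond the scatter), so the single amino group does not hold even the weaker of the two earlier readings.

On these data alone, how far the true value of compound 3 lies past its limit stays open, and with it the full size of both steps. Also open, as far as these compounds go, is whether the loss follows from the arrival of amino or from the departure of trifluoromethyl, a question that a methyl group, a chlorine atom, a nitrile or a dimethylamino group on the same aromatic carbon would help to settle.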